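From nitrile to bromomethyl ketone on a fluorinated ring

The source may report more compounds than this note shows. Statements on the series, on what has been measured and on what is new or still open speak of the compounds shown alone.

Compound 3 `N#Cc1cc(C(F)(F)F)cc(C(F)(F)F)c1` carries a cyano group on its aromatic core. In an ADME assay for pharmacokinetics, read by LC-MS, in phosphate buffer, with a stated time of 72 h, at pH 7.4, tested at 250 uM (a lower number here means that the compound disappears faster, a higher number that the compound lasts longer), compound 3 gives > 50 h, which is a limit of the assay rather than a number. Compound 2 `C#Cc1cc(C(F)(F)F)cc(C(F)(F)F)c1` gives > 50 h in this assay, also a limit. Compound 1 `C=CC(=O)Oc1cc(C(F)(F)F)cc(C(F)(F)F)c1` gives < 0.017 h in this assay, a limit as well. Two of the three values sit at the limit of > 50 h in this assay, at which 2 of the 3 values shown sit, and one at the limit of < 0.017 h in this assay, at which 1 of the 3 values shown sits, so compound 3 stands at the long-lived end of what has been seen. The move to compound 4 `O=C(CBr)c1cc(C(F)(F)F)cc(C(F)(F)F)c1` replaces the cyano group: (bromomethyl)carbonyl in place of cyano on an aromatic carbon. Among the compounds with values here, none of the measured steps made this exact change. The steps of an at least 2900-fold higher number from compound 1 to compound 3 (3.46 log units; beyond the scatter) and an at least 2900-fold higher number from compound 1 to compound 2 (3.46 log units; beyond the scatter) show that exchanging the group on that carbon can move the half-life very far, while a step that the two limits leave unreadable from compound 2 to compound 3 cannot be read. A step of an at least 10-fold lower number from compound 3 to compound 4 (1.00 log units; beyond the scatter) in this assay is expected, toward a shorter half-life. The estimate for compound 4 is 5 h, between 0.5 h and 50 h.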

Compound 4, half-life: < 0.017 h
Compound 4: only a limit was reported (the forecaster's own chance of this, stated with the estimate: 15%); middle value at least 290-fold (2.46 log units) from the limit.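

The change gives an at least 2900-fold lower number from compound 3 to compound 4 (3.46 log units; beyond the scatter) and an at least 2900-fold lower number from compound 2 to compound 4 (3.46 log units; beyond the scatter) in this assay, so a short half-life on this aromatic carbon is no longer tied to the (vinylcarbonyl)oxy group of compound 1. The step from compound 1 to compound 4 cannot be read, so these two groups cannot be ranked against each other. The compounds now fall only at the two ends of what the assay can report, and the short-lived end holds as many as the long-lived end: the limit of < 0.017 h in this assay, at which 2 of the 4 values shown sit.

On these data alone, the true half-life of each of the four compounds remains open, since all of them sit at a limit. Also open, as far as these compounds go, is how a plain acetyl group, which lacks the bromine, or an amine on this same carbon would behave.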